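Ethoxy to nitro on the aryl imine of compound 1

The source may hold more compounds than are shown below. What is called first, only, known or untested is meant among the compounds shown, and "the series" means these compounds.

Measured compounds:
compound 1 `CCOc1cccc(/C=N/c2c(C)n(C)n(-c3ccccc3)c2=O)c1`: 295000000 nM
compound 2 `COc1ccc(/C=N/c2c(C)n(C)n(-c3ccccc3)c2=O)cc1`: 186000000 nM
compound 3 `COc1ccc(/C=N/c2c(C)n(C)n(-c3ccccc3)c2=O)cc1OC`: 141000000 nM

In a functional assay on P388 cells (Mus musculus) for cytotoxicity, read by MTT assay, with a stated time of 72 h (a higher number here means a weaker inhibitor, a lower number a stronger inhibitor), compound 1 gives the highest of the three numbers; compound 2 is nearest, compound 3 furthest, and only the gap to compound 3 lies beyond the scatter. Going by the values given here, the one step that is computed, a 1.3-fold lower number from compound 2 to compound 3 (0.12 log units; within the scatter), concerns a methoxy added to the shared core and stays within the scatter.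

Compound 4 `Cc1c(/N=C/c2cccc([N+](=O)[O-])c2)c(=O)n(-c2ccccc2)n1C` differs from compound 1 by nitro in place of ethoxy on an aromatic carbon. Among the compounds with values here, no measured step covers this change; the methoxy step of compound 2 to compound 3 is the only comparison and it is flat. The series is therefore expected to remain flat here, with an estimated step of a 1.2-fold lower number from compound 1 to compound 4 (0.07 log units; within the scatter) in this assay. Compound 4 is thus estimated at 250000000 nM, within 100000000 nM to 600000000 nM.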

Compound 4, half-maximal inhibitory concentration: 490000000 nM
Compound 4: the middle estimate sits 2.0-fold (0.29 log units) below what was measured; the range from low to high includes it.
By their numbers in this assay, from the lowest: compounds 3, 2, 1 and 4 (each within the scatter of the next, the first and the last beyond it).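

Nitro in place of ethoxy on an aromatic carbon, meta to a large group, gives a 1.7-fold higher number from compound 1 to compound 4 (0.22 log units; within the scatter) in this assay. This is the first change shown at this position, and the two groups, which share a heavy-atom count but differ in their atoms, stay within the scatter of each other. No measurement here bears on what lies behind this reading.

On these data alone, whether an amine or a carboxylic acid on this aromatic carbon would leave the number as flat remains open. As far as these compounds go, a longer chain in place of ethoxy is equally open.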